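This account rests on a few compounds, and the source may have more. Where it says the series, first, only, none or still open, it means among the compounds named here.

Series values in an ADME assay on a cell-free system (plasma, Mus musculus, strain CD-1) for protein binding:
- compound 1 `CCCS(=O)(=O)Nc1ccc(F)c(C(=O)Nc2cnc3[nH]ncc3c2)c1F`: 87.1%
- compound 2 `CCCS(=O)(=O)Nc1ccc(F)c(C(=O)Nc2cnc3[nH]nc(C)c3c2)c1F`: 89.9%
- compound 3 `CCCS(=O)(=O)Nc1ccc(F)c(C(=O)Nc2cnc3[nH]cc(Br)c3c2)c1F`: 99.4%

Compound 2, at 89.9%, has the second highest unbound fraction of the three. It lies within the scatter of compound 1. Compound 3, at 99.4%, has much less free compound, well beyond the scatter. However, compound 3 differs from compound 2 in more than one place, so it offers no clean step.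

The next compound is compound 4 `CCCS(=O)(=O)Nc1ccc(F)c(C(=O)Nc2cnc3[nH]nc(N(C)C)c3c2)c1F`, with dimethylamino in place of methyl on an aromatic carbon.

Within the data shown here, only one measured step bears on this aromatic carbon, methyl in place of hydrogen: a 1.3-fold lower unbound fraction from compound 1 to compound 2 (0.11 log units; within the scatter). Among the measured compounds shown here, that step is small, and no dimethylamino analogue has been measured, so the evidence is thin. A modest shift towards more binding is the working assumption, with no firm expectation of a change beyond the scatter. The range stays wider on the high side, given that compound 3 reached 99.4% in this assay.

The expected step is a 1.3-fold lower unbound fraction from compound 2 to compound 4 (0.10 log units; within the scatter). Compound 4 is estimated at 92%, with an expected range of 86% to 97%.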

Compound 4, plasma protein binding in the plasma assay: 90.8%
Beside the measured number, compound 4's estimate is 1.2-fold (0.06 log units) (unbound fraction) below it, and the stated range covers the measured number.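

In the plasma assay, compound 4 stands at 90.8%, compound 2 at 89.9% and compound 1 at 87.1%: dimethylamino in place of methyl on this aromatic carbon of the five-membered ring gives a 1.1-fold lower unbound fraction from compound 2 to compound 4 (0.04 log units; within the scatter), and dimethylamino in place of hydrogen gives a 1.4-fold lower unbound fraction from compound 1 to compound 4 (0.15 log units; within the scatter), so these steps do not separate hydrogen, methyl and dimethylamino at this position. In a physicochemical assay for solubility, read by HPLC, in phosphate buffer, with a stated time of 24 h, at pH 6.5 (a lower number here means a less soluble compound, a higher number a more soluble compound), the same exchange gives a 1.3-fold lower number from compound 2 to compound 4 (0.12 log units; within the scatter), with compound 2 at 380 ug/mL and compound 4 at 290 ug/mL, so the larger group with its added nitrogen shifts neither read-out beyond the scatter between compound 2 and compound 4. Nothing available explains why this position shows so little response in either read-out.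

Going by these compounds, it remains open whether a carboxylic acid, a primary amine or a longer alkyl chain on this aromatic carbon would give a step beyond the scatter in the plasma assay, since the three groups compared here cover only a narrow set of substituents. Also in the plasma assay, compound 3 stands at 99.4% but differs from compound 2 in more than one place, so its high binding cannot be assigned to any single change in the shared core.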